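The source may hold more compounds than are shown below. What is called first, only, known or untested is meant among the compounds shown, and "the series" means these compounds.

Measured so far in an assay on thoracic aorta for binding affinity to Alpha-1A adrenergic receptor (Rattus norvegicus); on this read-out higher numbers stand for weaker binding and lower numbers for tighter binding:
compound 1 `COc1cc(=O)oc2cc(OCCCN3CCN(c4ccccc4)CC3)ccc12` gives 355 nM;
compound 2 `COc1cc(=O)oc2cc(OCCCN3CCN(c4ccccn4)CC3)ccc12` gives 191 nM.

Compound 2 stands nearest compound 1, and the step of a 1.9-fold lower number from compound 1 to compound 2 (0.27 log units; within the scatter) lies within the scatter, so the two cannot be ranked against each other. Compound 3 `COc1cc(=O)oc2cc(OCCCN3CCN(c4ncccn4)CC3)ccc12` carries pyrimidin-2-yl in place of pyridin-2-yl on an amine nitrogen in a ring. Within the data shown here, the only measured step that bears on this change is the earlier exchange on the same ring nitrogen, a 1.9-fold lower number from compound 1 to compound 2 (0.27 log units; within the scatter), which stayed within the scatter. The step of a 1.0-fold higher number from compound 2 to compound 3 (0.02 log units; within the scatter) in this assay is therefore expected to be no larger than the scatter, with no direction claimed. Compound 3 is expected to give 200 nM, in the range 90 nM to 450 nM.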

Compound 3, dissociation constant: 44.7 nM
The estimate for compound 3 lay 4.5-fold (0.65 log units) above the measured number, and the stated range ends above it.
By their numbers in this assay, from the lowest: compound 3; then compounds 2 and 1 (each within the scatter of the next).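

On the amine nitrogen in the ring, pyrimidin-2-yl in place of pyridin-2-yl gives a step beyond the scatter in this assay: a 4.3-fold lower number from compound 2 to compound 3 (0.63 log units; beyond the scatter). Unlike the exchange of phenyl for pyridin-2-yl, this shows that the group on this nitrogen can move the number, and the step with phenyl as its start also lies beyond the scatter: a 7.9-fold lower number from compound 1 to compound 3 (0.90 log units; beyond the scatter). Nothing available explains this step.

Going by these compounds, whether a pyrazinyl group on the same nitrogen would keep the number as low stays open. So does whether pyrimidin-2-yl would hold this advantage with a longer chain to the shared core.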